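Arylpiperazine sulfonylbenzamide series: 4-chlorophenyl replacing pyrimidinyl

This account rests on a few compounds, and the source may have more. Where it says the series, first, only, none or still open, it means among the compounds named here.

Two compounds of the series have numbers in an assay on HEK293 cells for displacement of a labelled ligand from 5-hydroxytryptamine receptor 6 (Homo sapiens); on this read-out lower numbers stand for stronger inhibition and higher numbers for weaker inhibition. Compound 1 `O=C1c2ccccc2S(=O)(=O)N1CCCCCN1CCN(c2ccccc2)CC1` gives 1840 nM. Compound 2 `O=C1c2ccccc2S(=O)(=O)N1CCCCCCN1CCN(c2ncccn2)CC1` gives 5710 nM, the highest of the two numbers; the nearest is compound 1, which sits a good way lower, beyond the usual scatter. Compound 1 and compound 2 differ in two places, the aryl group on the piperazine and the linker, so the two values can be compared only as they stand, and no single change can be read from them.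

Compound 3 `O=C1c2ccccc2S(=O)(=O)N1CCCCCCN1CCN(c2ccc(Cl)cc2)CC1` has not yet been measured in this assay. It differs from compound 2 in one place: 4-chlorophenyl in place of pyrimidin-2-yl on an amine nitrogen in a ring. Among the measured compounds shown here, there is no measured pair that shows this exchange alone. For the measured compounds named here, on the information at hand, the expectation is a moderate step downward, beyond the scatter, from compound 2 to compound 3 in this assay, a 3.8-fold lower number from compound 2 to compound 3 (0.58 log units; beyond the scatter), with wide uncertainty since the exchange of aryl group has no direct precedent here. Compound 3 is accordingly estimated at 1500 nM, the range running from 400 nM to 6000 nM.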

Compound 3, inhibition constant: 72 nM
Compound 3: middle estimate off by 21-fold (1.32 log units), on the high side; the whole stated range lies above it.
By their numbers in this assay, from the lowest: compound 3; then compound 1; then compound 2.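

In this assay, among the compounds shown here, the exchange of pyrimidin-2-yl for 4-chlorophenyl on the amine nitrogen in a ring gives a 79-fold lower number from compound 2 to compound 3 (1.90 log units; beyond the scatter) with the rest of the structure unchanged, and this is the first change in a single place that can be read. It shows that the group at this position can by itself move the read-out by a large step, which the earlier pair, differing in two places, could not show. The exchange replaces a ring with 2 hetero atoms and 2 hydrogen-bond acceptors by a ring of carbon only that bears chlorine, and no measurement at hand says which part of this exchange matters or accounts for the size of the step.

Still open, as far as these compounds go, is how much of the step belongs to the chlorine and how much to the carbon-only ring, which a plain phenyl on the same linker, a pyridine ring, or fluorine in place of chlorine would help to separate. The contribution of the linker also remains unresolved, since compound 1 differs from compound 3 in two places, and a shorter or longer chain carrying 4-chlorophenyl would address it.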